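The source may report more compounds than this note shows. Statements on the series, on what has been measured and on what is new or still open speak of the compounds shown alone.

Compound 1 `S=C(N/N=C/c1cccc2ccccc12)Nc1ccccc1`: 500 nM
Compound 2 `S=C(N/N=C/c1cccc2ccccc12)Nc1ccc(Cl)cc1`: 1900 nM
Compound 3 `COc1ccc(NC(=S)N/N=C/c2cccc3ccccc23)cc1`: 860 nM

All three values come from a functional assay on B16 cells (Mus musculus), read by spectrophotometry, with a stated time of 3 days (on this read-out higher numbers stand for weaker inhibition and lower numbers for stronger inhibition), and share one core. Chloro in place of hydrogen on an aromatic carbon gave a 3.8-fold higher number from compound 1 to compound 2 (0.58 log units; beyond the scatter) in this series. Among the compounds with values here, compound 3 stands within the scatter of compound 1 (a 1.7-fold higher number from compound 1 to compound 3 (0.24 log units; within the scatter)) and clear of compound 2 (a 2.2-fold lower number from compound 2 to compound 3 (0.34 log units; beyond the scatter)) on the numbers so far.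

Compound 4 `COc1ccccc1NC(=S)N/N=C/c1cccc2ccccc12` has not yet been measured. It has the same atoms as compound 3 joined differently (2-methoxyphenyl in place of 4-methoxyphenyl on an amide-type nitrogen), with 2-methoxyphenyl in place of 4-methoxyphenyl on an amide-type nitrogen. Within the data shown here, no measured compound carries a 2-methoxyphenyl group, so no step tests this change directly. The closest evidence is the methoxy step (a 1.7-fold higher number from compound 1 to compound 3 (0.24 log units; within the scatter)), which stayed within the scatter, so no clear shift is expected, though the uncertainty stays wide.

The expected step in this assay is a 1.1-fold lower number from compound 3 to compound 4 (0.03 log units; within the scatter) and would not go beyond the scatter. The estimate for compound 4 is 800 nM, with an expected range from 300 nM to 2200 nM.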

Compound 4, half-maximal inhibitory concentration: 920 nM
Beside the measured number, compound 4's estimate is 1.2-fold (0.06 log units) below it, within the range that was stated.
By their numbers in this assay, from the lowest: compounds 1, 3 and 4 (each within the scatter of the next); then compound 2.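

Placing the methoxy group as 2-methoxyphenyl rather than 4-methoxyphenyl on the amide-type nitrogen gives no reading that can be told apart in this assay, with a 1.1-fold higher number from compound 3 to compound 4 (0.03 log units; within the scatter). The 2-methoxyphenyl compound also stays level with the unsubstituted phenyl compound, at a 1.8-fold higher number from compound 1 to compound 4 (0.26 log units; within the scatter), yet it stands clear of the 4-chlorophenyl compound, at a 2.1-fold lower number from compound 2 to compound 4 (0.31 log units; beyond the scatter), so among these four compounds only compound 2 stands apart from the others. No measured evidence is available to explain this result.

The compounds shown leave open whether a different kind of group on this ring, such as an amine or a carboxylic acid, would move the number beyond the scatter of compound 1. They also leave open whether chloro, like methoxy, reads the same when placed elsewhere on the ring.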